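This account rests on a few compounds, and the source may have more. Where it says the series, first, only, none or still open, it means among the compounds named here.

Measured so far in this series:
Compound 1, `COc1nc2ccc(Br)cc2cc1C(c1ccccc1)n1cc(-c2ccc(Br)cc2)nn1`, gives 13.4%.
Compound 2, `COc1nc2ccc(Br)cc2cc1C(c1ccccc1)n1cc(-c2ccccc2F)nn1`, gives 7.33%.
Compound 3, `CCCc1cn(C(c2ccccc2)c2cc3cc(Br)ccc3nc2OC)nn1`, gives 11.2%.

Read-out throughout is an ADME assay on SK-OV-3 cells (Homo sapiens) for cytotoxicity, read by sulforhodamine B assay, with a stated time of 48 h, tested at 10 uM; a higher number here means more inhibition at the concentration tested (going by the name of the read-out), a lower number less inhibition. Compound 3 stands second highest of the three numbers; the steps among the three are a number 2.2 percentage points lower from compound 1 to compound 3 (within the scatter), a number 3.9 percentage points higher from compound 2 to compound 3 (within the scatter), and a number 6.1 percentage points lower from compound 1 to compound 2 (within the scatter). All three measured numbers therefore sit within one another's scatter.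

Compound 4, `COc1nc2ccc(Br)cc2cc1C(c1ccccc1)n1cc(C2CC2)nn1`, differs from compound 3 by cyclopropyl in place of propyl on an aromatic carbon. Going by the values given here, the two steps that bear on this site, the one from compound 1 to compound 3 and the one from compound 2 to compound 3, were both within the scatter, so no step beyond the scatter is expected here, a number 0.2 percentage points lower from compound 3 to compound 4 (within the scatter). Compound 4 is estimated at 11%, with a range of 3% to 20%.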

Compound 4, a percentage reported as inhibition, at one concentration (the size of the read-out at that concentration, not a potency): 3.52%
Estimate against measurement, compound 4: 7.5 percentage points above, and the stated range covers the measured number.
By their numbers in this assay, from the lowest: compounds 4, 2, 3 and 1 (each within the scatter of the next).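

In this assay cyclopropyl on this aromatic carbon adds a small carbon ring to the aryl groups and the propyl chain already read here, with a number 7.7 percentage points lower from compound 3 to compound 4 (within the scatter) and a number 3.8 percentage points lower from compound 2 to compound 4 (within the scatter) and a number 9.9 percentage points lower from compound 1 to compound 4 (within the scatter) all inside the scatter. The four groups at this position therefore give numbers that cannot be told apart, so no response to the change at this position is visible yet. Nothing on hand explains these numbers. On these data alone, an amine, a carboxylic acid or a longer chain at this position remains open, as does whether any group here gives a step beyond the scatter.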